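This account rests on a few compounds, and the source may have more. Where it says the series, first, only, none or still open, it means among the compounds named here.

Measured so far:
- compound 1 `COc1cc(OCc2ccccc2OC)c2cc(-c3cn4nc(OC)sc4n3)oc2c1` — 19 nM
- compound 2 `COc1cc(OCc2ccccc2OCc2ccccc2)c2cc(-c3cn4nc(OC)sc4n3)oc2c1` — 3.2 nM

Going by the values given here, in a functional assay on HEK293 cells for antagonist activity at proteinase-activated receptor 4 (Homo sapiens), read by FLIPR and calcium flux, with a stated time of 30 min (on this read-out higher numbers stand for weaker inhibition and lower numbers for stronger inhibition), compound 1 gives 19 nM, the higher of the two numbers recorded; the only neighbour is compound 2, reached by a 5.9-fold lower number from compound 1 to compound 2 (0.77 log units; beyond the scatter), which puts phenyl in place of hydrogen on a saturated chain carbon bound to an oxygen on an aromatic ring.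

Compound 3 `COc1cc(OCc2cccc(O)c2)c2cc(-c3cn4nc(OC)sc4n3)oc2c1` is not yet measured in this assay. It differs from compound 1 by 3-hydroxyphenyl in place of 2-methoxyphenyl on a saturated chain carbon bound to an oxygen on an aromatic ring. Among the compounds with values here, the one measured step, from compound 1 to compound 2, alters a different part of the molecule and says nothing about swapping one substituted phenyl for another at this place; no measured pair bears on the change to compound 3. Given this, no direction beyond the scatter is expected, and the estimate for compound 3 is 30 nM (range 8 nM to 120 nM), a step of a 1.6-fold higher number from compound 1 to compound 3 (0.20 log units; within the scatter) expected from compound 1.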

Compound 3, half-maximal inhibitory concentration: 3.1 nM
Estimate against measurement, compound 3: 9.7-fold (0.99 log units) above, outside the stated range (below it).
By their numbers in this assay, from the lowest: compounds 3 and 2 (each within the scatter of the next); then compound 1.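

In this assay, 3-hydroxyphenyl in place of 2-methoxyphenyl on a saturated chain carbon bound to an oxygen on an aromatic ring gives a 6.1-fold lower number from compound 1 to compound 3 (0.79 log units; beyond the scatter), so this position responds to a swap of one substituted phenyl for another, and not only to the added phenyl of compound 2. Compound 3 and compound 2 lie within the scatter of each other, so a number at this level does not depend on that added phenyl. No measurement shown here accounts for this step.

The step changes both the substituent and where it sits on the phenyl, and the compounds shown do not separate the two. From the compounds shown here alone, whether an amine or a carboxylic acid in place of the hydroxy group would keep the number at this level also remains open.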